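Pyrrolidinyl for cyclopentyl on the shared core

A few compounds are considered here, and "the series" means these few. Any claim that something is new, unique, unknown or untested is made for them only; others in the source may bear on it.

Measured so far:
compound 1, `COc1cnc(-c2ccccn2)nc1C1CCCC1`: 749 mL/min/kg
compound 2, `COc1cnc(-c2ccccn2)nc1NCc1ccccc1`: 67 mL/min/kg

In an in vitro ADME assay on microsomes from liver (Homo sapiens) for metabolic stability, read by LC-MS, tested at 0.05 uM (on this read-out higher numbers stand for fast clearance and lower numbers for slow clearance), compound 1 stands highest of the two numbers; compound 2, which carries a benzylamino group at the same position, gives a lower value, a gap beyond the scatter. Among the compounds with values here, no step between measured compounds is available. Compound 3, `COc1cnc(-c2ccccn2)nc1N1CCCC1`, differs from compound 1 by pyrrolidin-1-yl in place of cyclopentyl on an aromatic carbon. Since compound 2 with its nitrogen-linked group gives 67 mL/min/kg, a decrease beyond the scatter is expected, estimated as a 3.4-fold lower number from compound 1 to compound 3 (0.53 log units; beyond the scatter). Compound 3 is estimated at 220 mL/min/kg, between 70 mL/min/kg and 600 mL/min/kg.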

Compound 3, clearance: 458 mL/min/kg
Beside the measured number, compound 3's estimate is 2.1-fold (0.32 log units) below it, within the range that was stated.
By their numbers in this assay, from the lowest: compound 2; then compounds 3 and 1 (each within the scatter of the next).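

Pyrrolidin-1-yl in place of cyclopentyl on this aromatic carbon gives a 1.6-fold lower number from compound 1 to compound 3 (0.21 log units; within the scatter) in this assay, so this change of one ring atom to nitrogen does not separate the two compounds. A nitrogen link at this position therefore does not by itself match compound 2 at 67 mL/min/kg, as compound 3 gives 458 mL/min/kg. No measurement at hand bears on the reason for this result.

Open, going by these compounds, is how morpholin-4-yl or dimethylamino would read at this position, and whether the number of compound 2 follows from its benzyl group or its amino hydrogen.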